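This account rests on a few compounds, and the source may have more. Where it says the series, first, only, none or still open, it means among the compounds named here.

Measured compounds:
- compound 1, `CC(C)(C)OC(=O)N1CCC(n2ncc3c(Nc4ccc(S(C)(=O)=O)cc4F)ncnc32)CC1`: 8 ug/mL
- compound 2, `CC(C)OC(=O)N1CCC(n2ncc3c(Oc4ccc(S(C)(=O)=O)cc4)ncnc32)CC1`: < 1 ug/mL

The account follows a single change made to compound 2. In a physicochemical assay for solubility, measured as kinetic solubility, at pH 6.5 (a higher number here means a more soluble compound, a lower number a less soluble compound), compound 1 gives 8 ug/mL. For compound 2 the result is a limit of the assay rather than a number: in this assay compound 2 gives < 1 ug/mL, which is the limit of < 1 ug/mL in this assay, at which 1 of the 2 values shown sits. So compound 2 stands at the lower edge of what this assay can report, and its true value is unknown.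

Compound 3, `CS(=O)(=O)c1ccc(Oc2ncnc3c2cnn3C2CCN(Cc3ccc(C(F)(F)F)cc3)CC2)cc1`, differs from compound 2 in one place: 4-(trifluoromethyl)benzyl in place of isopropoxycarbonyl on an amine nitrogen in a ring. Going by the values given here, no measured pair shows a step of this kind, so the direction must be guessed. The author expects the solubility of compound 3 to rise above the limit seen for compound 2, by a modest step of an at least 4.0-fold higher number from compound 2 to compound 3 (0.60 log units; beyond the scatter). The estimate for compound 3 in this assay is 4 ug/mL, with a range from 0.8 ug/mL to 25 ug/mL.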

Compound 3, solubility: < 1 ug/mL
Compound 3 gave a limit, no number (the forecaster's own chance of this, stated with the estimate: 40%); middle value at least 4.0-fold (0.60 log units) away from the limit.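

In this assay compound 3 gives < 1 ug/mL, which is a limit of the assay and not a number. Compound 2 also gives a limit, so no step can be read between compound 2 and compound 3: the limit of < 1 ug/mL in this assay, at which 2 of the 3 values shown sit.

The compounds shown leave open how far either true value lies from that limit, and so what 4-(trifluoromethyl)benzyl in place of isopropoxycarbonyl does in this assay.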